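The source may report more compounds than this note shows. Statements on the series, on what has been measured and on what is new or still open speak of the compounds shown alone.

Working notes on the series. Compound 1 `CC(C)(C)[C@@H](O)C(=O)N1N=CC[C@H]1C(=O)NCc1cc(Cl)ccc1-n1cnnn1` and compound 2 `CCCC[C@@H](O)C(=O)N1N=CC[C@H]1C(=O)NCc1cc(Cl)ccc1-n1cnnn1` sit on one core; compound 3 `CC(C)(C)[C@@H](O)C(=O)N1[C@@H]2C[C@@H]2C[C@H]1C(=O)NCc1cc(Cl)ccc1-n1cnnn1` and compound 4 `CCCC[C@@H](O)C(=O)N1[C@@H]2C[C@@H]2C[C@H]1C(=O)NCc1cc(Cl)ccc1-n1cnnn1` sit on another. The difference between the two cores is not broken down here.

In an ADME assay on Caco-2 cells (Homo sapiens) for permeability, read by LC-MS, in the apical to basolateral direction, with a stated time of 60 min, at pH 6.5 (on this read-out lower numbers stand for lower permeability and higher numbers for higher permeability), compound 1 gives 15 10^-6 cm/s. In the same assay compound 2 gives 9.8 10^-6 cm/s. The change between the two is butyl in place of tert-butyl on a saturated chain carbon bound to a carbonyl carbon and an oxygen on a saturated carbon, and the step it made is a 1.5-fold lower number from compound 1 to compound 2 (0.18 log units; within the scatter), so the two numbers are not separated by more than the usual scatter.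

On the second core, compound 3 gives 34 10^-6 cm/s in this assay, the highest of the three measured numbers; its gaps to compound 1 and to compound 2 both lie beyond the scatter.

Compound 4 carries the same change as the first pair, on the core of compound 3: butyl in place of tert-butyl on a saturated chain carbon bound to a carbonyl carbon and an oxygen on a saturated carbon. The place of the change reads the same in both pairs, so this is the same change, made a second time. Among the compounds here it occurs twice in all.

The step from compound 3 to compound 4 in this assay is expected at about a 1.4-fold lower number from compound 3 to compound 4 (0.13 log units; within the scatter). Among the compounds with values here, this rests on the one earlier instance, which gave a 1.5-fold lower number from compound 1 to compound 2 (0.18 log units; within the scatter), a step within the scatter. Compound 4 is therefore estimated at 25 10^-6 cm/s in this assay. The expected range for compound 4 runs from 12 10^-6 cm/s to 45 10^-6 cm/s.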

Compound 4, apparent permeability: 35 10^-6 cm/s
The estimate for compound 4 lay 1.4-fold (0.15 log units) below the measured number, within the range that was stated.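

In this assay the second instance of butyl in place of tert-butyl gave a 1.0-fold higher number from compound 3 to compound 4 (0.01 log units; within the scatter), so on neither core does the change move the number beyond the scatter, and the two instances agree with each other: the same change on two cores in this assay, a 1.5-fold lower number (0.18 log units; within the scatter) from compound 1 to compound 2 and a 1.0-fold higher number (0.01 log units; within the scatter) from compound 3 to compound 4, 1.6-fold (0.20 log units) apart, within the scatter of two such steps. Within these four compounds, the change therefore carries from the core of compound 1 to the core of compound 3 with no step that can be told from the scatter, and no dependence on the core can be read from its size. This does not show that the change is strictly neutral, as two steps within the scatter do not separate a small shift from none, and two cores give no basis for a rule on a third core or on any other read-out.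

Both instances exchange only tert-butyl and butyl, so the compounds shown leave open whether another group at the same place, such as an amine, a carboxylic acid or a longer chain, would give a similar step on both cores. They also leave open whether any such group would give steps that agree across the two cores, as these two instances do.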